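A few compounds are considered here, and "the series" means these few. Any claim that something is new, unique, unknown or untested is made for them only; others in the source may bear on it.

Of the compounds shown here, three have been measured in a physicochemical assay for lipophilicity; on this read-out higher numbers stand for higher lipophilicity and lower numbers for lower lipophilicity. Compound 1 `N=C(N)Nc1cccc(C(=O)NNC(=O)CC(CC(=O)O)c2ccc(F)cc2)c1` gives 1.28, compound 2 `N=C(N)Nc1cccc(C(=O)NNC(=O)CC(CC(=O)O)c2ccc(Cl)cc2)c1` gives 1.68, and compound 3 `CC(=N)Nc1cccc(C(=O)NNC(=O)CC(CC(=O)O)c2ccc(F)cc2)c1` gives 1.6. Compound 3 stands beyond the scatter above compound 1 and within the scatter of compound 2. Two single-point steps connect the measured compounds: a number 0.40 log units higher from compound 1 to compound 2 (beyond the scatter), chloro in place of fluoro on an aromatic carbon, and a number 0.32 log units higher from compound 1 to compound 3 (beyond the scatter), methyl in place of amino on a carbon with a double bond to nitrogen.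

Compound 4 `COc1ccc(C(CC(=O)O)CC(=O)NNC(=O)c2cccc(NC(C)=N)c2)cc1` has not yet been measured. It differs from compound 3 in one place: methoxy in place of fluoro on an aromatic carbon. For the measured compounds named here, no measured step exchanges fluoro for methoxy; the one step at this position, a number 0.40 log units higher from compound 1 to compound 2 (beyond the scatter), swapped one halogen for another and does not settle the present change. Compound 4 is therefore expected to sit close to compound 3, with a number 0.15 log units lower from compound 3 to compound 4 (within the scatter) as the estimated shift, a step that is not expected to exceed the scatter. Compound 4 is estimated at 1.45, with a range from 1.1 to 1.8.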

Compound 4, partition coefficient: 1.31
Compound 4: middle estimate off by 0.14 log units, on the high side, and the stated range covers the measured number.
By their numbers in this assay, from the lowest: compounds 1, 4, 3 and 2 (each within the scatter of the next, the first and the last beyond it).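

With methoxy in place of fluoro on the aromatic carbon, this assay gives a number 0.29 log units lower from compound 3 to compound 4 (within the scatter) and so does not separate the 4-methoxyphenyl compound from the 4-fluorophenyl compound, even though the entering group brings one more heavy atom and one hydrogen-bond acceptor. The chloro for fluoro exchange at this position gave a number 0.40 log units higher from compound 1 to compound 2 (beyond the scatter) and lay beyond the scatter, so not every exchange here stays within it, although that step was read with amino rather than methyl on the carbon with a double bond to nitrogen. Nothing at hand accounts for the size of either step.

Going by these compounds, whether methoxy would read the same with that amino group in place remains open. So does the standing of hydroxy, trifluoromethyl or a longer ether such as ethoxy at this position.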